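The source may hold more compounds than are shown below. What is called first, only, known or untested is meant among the compounds shown, and "the series" means these compounds.

Measured compounds:
compound 1 `O=S1(=O)N=C(OCc2ccccc2)c2ccccc2N1Cc1ccc(Cl)c(Cl)c1` gives 30500 nM in a functional assay on CCRF-CEM cells (Homo sapiens) for inhibition; a higher number here means that more compound is tolerated, a lower number that less compound is tolerated
compound 2 `O=C(OCOCN1c2ccccc2C(=O)N(Cc2ccccc2)S1(=O)=O)c1ccccc1` gives 100000 nM in this assay

Compound 2 stands with the higher of the two numbers in this assay; compound 1 sits below it, beyond the scatter. Compound 3 `C#CCOCN1c2ccccc2C(=O)N(Cc2ccccc2)S1(=O)=O` is compound 2 with one change: ethynyl in place of benzoyloxy on a saturated chain carbon bound to an oxygen on a saturated carbon. Among the measured compounds shown here, no step between measured compounds bears on this change, so the expected size of the move rests on the two values alone. Compound 3 is expected to stay close to compound 2, with a step of a 1.7-fold lower number from compound 2 to compound 3 (0.22 log units; within the scatter) that may not exceed the scatter. Compound 3 is therefore estimated at 60000 nM, within 20000 nM to 150000 nM.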

Compound 3, half-maximal cytotoxic concentration: 23000 nM
Compound 3: middle estimate off by 2.6-fold (0.42 log units), on the high side; the measured number falls inside the stated range.
By their numbers in this assay, from the lowest: compounds 3 and 1 (each within the scatter of the next); then compound 2.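

Replacing benzoyloxy with ethynyl on a saturated chain carbon bound to an oxygen on a saturated carbon gives, in this assay, a 4.3-fold lower number from compound 2 to compound 3 (0.64 log units; beyond the scatter) as the first single-place step seen, a modest one beyond the scatter. The position therefore responds to what it carries, with less compound tolerated after (benzoyloxy)methyl gives way to propargyl. No measurement shown accounts for this move. Among the compounds shown here, the single step swaps the aromatic ring, the carbonyl and the triple bond together, and does not separate them. As far as these compounds go, how an amine, a carboxylic acid or a longer alkyl chain would read at this position remains open.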